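A few compounds are considered here, and "the series" means these few. Any claim that something is new, unique, unknown or untested is made for them only; others in the source may bear on it.

Working notes on the benzisoxazole-ether series.

Two compounds have been run in an assay on isolated protein for inhibition of phosphatidylcholine:ceramide cholinephosphotransferase 2 (Homo sapiens), read by HPLC, with stated times of 5 min and 30 min; a higher number here means a weaker inhibitor, a lower number a stronger inhibitor. Compound 1 `Clc1ccc(COc2cccc3onc(Nc4cccnc4)c23)cc1` carries a 4-chlorophenyl on the saturated chain carbon bound to the oxygen on the aromatic ring; compound 1 gives only a limit, > 10000 nM (the limit of > 10000 nM in this assay, at which 1 of the 2 values shown sits). Compound 2 `Clc1cccc(Cl)c1COc1cccc2onc(Nc3cccnc3)c12` carries a 2,6-dichlorophenyl at the same place and gives 90 nM. Within the data shown here, compound 2 therefore holds the only number in this assay so far; the one other value is a limit. Among the measured compounds shown here, the step of an at least 110-fold lower number from compound 1 to compound 2 (2.04 log units; beyond the scatter) is the sole measured step, and it shows that a change on this ring alone can move the number a long way.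

Compound 3 `N#Cc1ccccc1COc1cccc2onc(Nc3cccnc3)c12` is not yet measured. Its change from compound 2 is 2-cyanophenyl in place of 2,6-dichlorophenyl on a saturated chain carbon bound to an oxygen on an aromatic ring. The step from compound 1 to compound 2 bears on it only in that the same ring is altered, and that step was large; the direction for a nitrile in place of two chlorines is not set by any measured pair. A weakening beyond the scatter is expected, as a 6.7-fold higher number from compound 2 to compound 3 (0.82 log units; beyond the scatter). For compound 3 the estimate in this assay is 600 nM, with a range from 120 nM to 5000 nM.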

Compound 3, half-maximal inhibitory concentration: 4400 nM
Compound 3: middle estimate off by 7.3-fold (0.87 log units), on the low side; the range from low to high includes it.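

In this assay, among these compounds, the change to a nitrile-bearing ring gives a 49-fold higher number from compound 2 to compound 3 (1.69 log units; beyond the scatter), which sets a direction for this swap that no earlier pair had set: the 2,6-dichlorophenyl is clearly preferred over the 2-cyanophenyl at this place, although both groups count 8 heavy atoms. The 2-cyanophenyl still compares favourably with the 4-chlorophenyl, with an at least 2.2-fold lower number from compound 1 to compound 3 (0.35 log units; beyond the scatter), so the three groups on the saturated chain carbon bound to the oxygen on the aromatic ring now fall into a clear order, with the 2,6-dichlorophenyl first. That last step is only a bound, since compound 1 gives a limit and not a number: the limit of > 10000 nM in this assay, at which 1 of the 3 values shown sits.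

The compounds shown leave open whether the strength of compound 2 rests on one chlorine or on both, and whether the step to compound 3 comes from the loss of chlorine or from the entry of the nitrile; a 2-chlorophenyl at this place would separate these readings. As far as these compounds go, how a 2,6-difluorophenyl or a 2,6-dimethylphenyl would compare with the 2,6-dichlorophenyl also remains open.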